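The source may hold more compounds than are shown below. What is called first, only, known or untested is meant among the compounds shown, and "the series" means these compounds.

Measured compounds:

Compound 1 `CCC(CC)Nc1ncnc2c1ncn2C1O[C@H](CO)[C@@H](O)[C@H]1O` gives 0.75 nM in an assay on cell membranes for binding affinity to adenosine receptor A1 (Cavia porcellus), read by radioligand binding; on this read-out lower numbers stand for stronger inhibition and higher numbers for weaker inhibition.
Compound 2 `CCCn1c(=O)c2nc([C@@H]3CC4C=CC3C4)[nH]c2n(CCC)c1=O` gives 4.3 nM in this assay.
Compound 3 `CC1(Nc2ncnc3c2ncn3C2O[C@H](CO)[C@@H](O)[C@H]2O)CCCCC1` gives 70 nM in this assay.

Compound 2 holds the second highest of these three numbers. Compound 1 sits nearest, with a lower number, while compound 3 lies furthest away, with a higher number; both of these gaps are beyond the scatter.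

Compound 4 `CCCn1c(=O)c2nc([C@@H]3CC4CCC3C4)[nH]c2n(CCC)c1=O` has not yet been measured. It differs from compound 2 in one place: a group of 7 heavy atoms (7 carbon; 2 five-membered non-aromatic rings of carbon only) in place of a group of 7 heavy atoms (7 carbon; 2 five-membered non-aromatic rings of carbon only), on an aromatic carbon. The group that enters and the group that leaves match in their count of carbon atoms and in their two five-membered non-aromatic rings of carbon only.

Within the data shown here, the only measured step between two compounds that differ in one place, a 93-fold higher number from compound 1 to compound 3 (1.97 log units; beyond the scatter), concerns a nitrogen on a different shared core and a change of a quite different kind, so it says little about this one. Among the measured compounds shown here, no step among the measured compounds touches the group on the aromatic carbon of compound 2. With nothing pointing either way, a small step is expected, possibly none beyond the scatter, so compound 4 is estimated at 5 nM with a range from 1.5 nM to 15 nM, which means a 1.2-fold higher number from compound 2 to compound 4 (0.07 log units; within the scatter).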

Compound 4, inhibition constant: 3.8 nM
Beside the measured number, compound 4's estimate is 1.3-fold (0.12 log units) above it, and the stated range covers the measured number.
By their numbers in this assay, from the lowest: compound 1; then compounds 4 and 2 (each within the scatter of the next); then compound 3.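

In this assay the swap on the aromatic carbon, between two ring nitrogen atoms, is a step of a 1.1-fold lower number from compound 2 to compound 4 (0.05 log units; within the scatter) and so no real change. The group that leaves carries one double bond outside aromatic rings and the group that enters has none, yet both have the same two five-membered non-aromatic rings of carbon only, so at this position the double bond can be lost without any difference this measurement can detect. Nothing available explains this result.

Only these two closely matched carbon groups are seen at this position, so a phenyl ring, an amine or a straight pentyl chain there could give a very different number. From the compounds shown here alone, whether the double bond also makes no difference at other adenosine receptors remains open.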